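A few compounds are considered here, and "the series" means these few. Any claim that something is new, unique, unknown or untested is made for them only; others in the source may bear on it.

Compound 1 `CCOC(=O)c1cc(C)cc(NNC(=O)Nc2cc(Cl)nc(Cl)c2)n1`: in a functional assay on CHO cells for agonist activity at sphingosine 1-phosphate receptor 2 (Homo sapiens), read by fluorescence and calcium flux, with a stated time of 3 min (a lower number here means a stronger inhibitor, a higher number a weaker inhibitor), compound 1 gives > 23000 nM, which is a limit of the assay and not a number.
Compound 2 `Cc1cc(NNC(=O)Nc2cc(Cl)nc(Cl)c2)nc(-c2cnn(C)c2)c1`: in this assay compound 2 gives > 23000 nM, again a limit of the assay rather than a number.

Compound 2 therefore stands at the limit only; both values shown in the series sit at the limit of > 23000 nM in this assay, at which 2 of the 2 values shown sit, so nothing within the series separates compound 2 from compound 1 on the numbers.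

Compound 3 `Cc1cc(NNC(=O)Nc2cc(Cl)nc(Cl)c2)nc(-c2ccc(F)cc2)c1` is not yet measured. It differs from compound 2 in one place: 4-fluorophenyl in place of 1-methyl-1H-pyrazol-4-yl on an aromatic carbon.

Within the data shown here, the only measured step that bears on this position is a step that the two limits leave unreadable from compound 1 to compound 2; with both ends at the limit its size cannot be read, so it gives no direction for a change at this carbon. Among the measured compounds shown here, no other pair touches the same position.

On that basis the expectation for compound 3 is that the step from compound 2 to compound 3 in this assay, a step that the limit leaves unreadable from compound 2 to compound 3, shows nothing beyond the scatter and that compound 3 again returns a limit. The estimate for compound 3 in this assay is 40000 nM, with a range from 15000 nM to 100000 nM.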

Compound 3, half-maximal inhibitory concentration: > 23000 nM
Compound 3 ended at the assay's limit; the forecaster's own chance of this, stated with the estimate: 85%; the middle value does not contradict the limit.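

Compound 3 gives > 23000 nM in this assay, a limit of the assay and not a number. No step among compound 1, compound 2 and compound 3 can be read, as all three sit at the same limit: the limit of > 23000 nM in this assay, at which 3 of the 3 values shown sit.

The compounds shown leave open whether any group at this aromatic carbon gives a readable value in this assay.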